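The compounds below may be only part of what the source reports. "The series", "measured", "known", "first", "only" and "open" are said of these compounds alone.

Compound 1 `COc1ccc(-c2cc3ccccc3c(-c3ccc(O)cc3)n2)cc1` is the starting point of this small set. In a functional assay on HCT-15 cells (Homo sapiens) for cytotoxicity, read by CCK-8 assay and cell counting, with a stated time of 72 h (a higher number here means a weaker inhibitor, a lower number a stronger inhibitor), compound 1 gives > 50000 nM, which is a limit of the assay rather than a number (the limit of > 50000 nM in this assay, at which 1 of the 3 values shown sits). Compound 2 `COc1ccc(-c2cc3ccccc3c(-c3ccc(OC)cc3)n2)cc1` differs from compound 1 by methyl in place of hydrogen on an oxygen on an aromatic ring. In this assay compound 2 gives 2790 nM, so that an at least 17-fold lower number from compound 1 to compound 2 (1.25 log units; beyond the scatter). Compound 3 `COc1cc(OC)cc(-c2cc3ccccc3c(-c3cccc(O)c3)n2)c1` carries a different set of groups; how its core differs from the core of compound 1 is not broken down here. In this assay compound 3 gives 840 nM, the lowest number of the measured compounds, with compound 2 as its nearest neighbour. Compound 4 `COc1cc(OC)cc(-c2cc3ccccc3c(-c3cccc(OC)c3)n2)c1` has not been measured; it differs from compound 3 by methyl in place of hydrogen on an oxygen on an aromatic ring. The place of the change reads the same as in the earlier pair, but one bond further out it is 3-hydroxyphenyl to 3-methoxyphenyl rather than 4-hydroxyphenyl to 4-methoxyphenyl, so it is the same kind of change made on a different compound. The earlier step began at a limit, so its true size is known only as a minimum. For compound 4 a more modest downward step is expected, estimated as a 2.4-fold lower number from compound 3 to compound 4 (0.38 log units; beyond the scatter), because compound 3 already stands at 840 nM and the scatter of the method leaves the smaller step uncertain. In this assay compound 4 is expected to give about 350 nM, with a likely range from 100 nM to 1500 nM.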

Compound 4, half-maximal inhibitory concentration: 1170 nM
Compound 4: the middle estimate sits 3.3-fold (0.52 log units) below what was measured, within the range that was stated.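

In this assay, methyl in place of hydrogen on an oxygen on an aromatic ring gives a 1.4-fold higher number from compound 3 to compound 4 (0.14 log units; within the scatter), so compound 3 and compound 4 cannot be told apart, and the large step seen on the core of compound 1 does not carry over to this core: the same change on two cores in this assay, an at least 17-fold lower number (1.25 log units; beyond the scatter) from compound 1 to compound 2 and a 1.4-fold higher number (0.14 log units; within the scatter) from compound 3 to compound 4, at least 24-fold (1.39 log units) apart, beyond the scatter of two such steps Compound 1 gives > 50000 nM, which is a limit of the assay and not a number, so the earlier step is known only as a minimum. The two pairs also differ from each other in other parts of their structures, so these results do not show which of those differences separates the two steps, and two pairs say nothing about how the change would behave on any further core.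

As far as these compounds go, it remains open whether a longer chain on that oxygen, or an amine or a carboxylic acid in place of the hydroxy group, would move the number beyond the scatter on either core. From the compounds shown here alone, it also remains open whether compound 3 and compound 4 would stay this close in a different cell line.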